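A few compounds are considered here, and "the series" means these few. Any claim that something is new, unique, unknown or untested is made for them only; others in the source may bear on it.

In a functional assay on HeLa S3 cells (Homo sapiens) for antiproliferative activity, read by XTT assay, with a stated time of 72 h (a lower number here means a stronger inhibitor, a higher number a weaker inhibitor), compound 1 `C#Cc1cn([C@@H]2O[C@H](CO)[C@@H](O)[C@H]2O)c2ncnc(NC)c12` gives > 20000 nM, which is a limit of the assay and not a number. Compound 2 `CN(C)c1ncnc2c1c(-c1ccsc1)cn2[C@@H]1O[C@H](CO)[C@@H](O)[C@H]1O` gives > 15000 nM, also only a limit, so no measured number fixes where it stands. Compound 3 `C#Cc1cn([C@@H]2O[C@H](CO)[C@@H](O)[C@H]2O)c2ncnc(N(C)C)c12` differs from compound 2 in one place: ethynyl in place of thiophen-3-yl on an aromatic carbon. Compound 1 also carries ethynyl and has the limit > 20000 nM, so no step beyond the scatter is expected in this assay. The expected step is a step that the limit leaves unreadable from compound 2 to compound 3. Compound 3 is expected near 20000 nM, within an estimated range of 8000 nM to 50000 nM.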

Compound 3, half-maximal inhibitory concentration: 810 nM
For compound 3 the middle estimate is 25-fold (1.39 log units) above the measured one, and the stated range ends above it.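

In this assay, compound 3 is the only one of the three with a measured number, and it carries both changes: ethynyl in place of thiophen-3-yl gives an at least 18-fold lower number from compound 2 to compound 3 (1.26 log units; beyond the scatter), and methyl in place of hydrogen on the nitrogen gives an at least 24-fold lower number from compound 1 to compound 3 (1.39 log units; beyond the scatter). Ethynyl on this aromatic carbon is therefore not enough alone, as compound 1 carries it too. Both steps are only minimum sizes: the values of compound 1 and compound 2 are limits of the assay.

On these data alone, what a nitrile or a longer chain such as propynyl on this carbon would give stays open, as does a free amino group on the shared core.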